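A few compounds are considered here, and "the series" means these few. Any claim that something is new, unique, unknown or untested is made for them only; others in the source may bear on it.

Compound 1 `CC(C)(C)OC(=O)/C=C1/C(=O)Nc2ccccc21` gives 83.3% in a functional assay on SAOS-2 cells (Homo sapiens) for inhibition, read by CCK-8 assay, with a stated time of 72 h, tested at 20 uM; on this read-out lower numbers stand for less inhibition of growth and higher numbers for more inhibition of growth at the one concentration tested. Compound 2 `CCCCc1ccc2c(c1)/C(=C\C(=O)OC(C)(C)C)C(=O)N2` gives 84.2% in this assay; the step of a number 0.9 percentage points higher from compound 1 to compound 2 (within the scatter) is within the scatter. Of the two numbers, compound 2 holds the higher, yet its gap to compound 1 is within the scatter, so the two are not distinguishable. Compound 3 `CC(C)(C)OC(=O)/C=C1/C(=O)Nc2ccc([N+](=O)[O-])cc21` differs from compound 2 in one place: nitro in place of butyl on an aromatic carbon. Going by the values given here, the one known step, a number 0.9 percentage points higher from compound 1 to compound 2 (within the scatter), swapped hydrogen for butyl rather than butyl for nitro, so it bears only loosely here; no step beyond the scatter is therefore expected in this assay. Compound 3 is estimated at 80%, within a range from 60% to 92%, an expected step of a number 4.2 percentage points lower from compound 2 to compound 3 (within the scatter).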

Compound 3, percent growth inhibition at one concentration: 82.8%
The estimate for compound 3 lay 2.8 percentage points below the measured number; low and high end bracket the measured number.
By their numbers in this assay, from the lowest: compounds 3, 1 and 2 (each within the scatter of the next).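

In this assay, nitro in place of butyl gives a number 1.4 percentage points lower from compound 2 to compound 3 (within the scatter), and nitro in place of hydrogen gives a number 0.5 percentage points lower from compound 1 to compound 3 (within the scatter). This aromatic carbon has now carried hydrogen, butyl and nitro, and no step among these three compounds goes beyond the scatter, even though nitro brings hydrogen-bond acceptors that butyl lacks. Nothing measured here explains this result.

As far as these compounds go, whether an amine, a carboxylic acid or a longer chain on this carbon would also stay within the scatter remains open. A single tested concentration also leaves open whether these three compounds would separate at lower concentrations.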